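Methoxy for bromo on the anilide ring of a pyrazole amide

The compounds below may be only part of what the source reports. "The series", "measured", "known", "first", "only" and "open" are said of these compounds alone.

Of the compounds shown here, three have been measured in a functional assay on MCF7 cells (Homo sapiens) for cytotoxicity, read by MTT assay, with a stated time of 48 h; on this read-out higher numbers stand for weaker inhibition and lower numbers for stronger inhibition. Compound 1 `O=C(Nc1ccc(Br)cc1)c1cn(-c2ccccc2)nc1-c1ccccc1` gives 5750 nM in this assay. Compound 2 `COc1ccc(NC(=O)c2cn(-c3ccccc3)nc2-c2ccccc2)cc1` differs from it by methoxy in place of bromo on an aromatic carbon and gives 1710 nM in this assay, a change of a 3.4-fold lower number from compound 1 to compound 2 (0.53 log units; beyond the scatter). Compound 3 `O=C(Nc1ccc(Br)cc1)c1cn(-c2ccccc2)nc1-c1ccc(Cl)cc1` carries a second change on the other aryl ring, (chloro in place of hydrogen on an aromatic carbon), and gives 5310 nM in this assay; the step of a 1.1-fold lower number from compound 1 to compound 3 (0.03 log units; within the scatter) is within the scatter, so compound 1 and compound 3 are read as alike.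

Compound 4 `COc1ccc(NC(=O)c2cn(-c3ccccc3)nc2-c2ccc(Cl)cc2)cc1` has not yet been measured. It differs from compound 3 by methoxy in place of bromo on an aromatic carbon. Going by the values given here, this is the same change as the one between compound 1 and compound 2, made on the same place and on the same ring, and the two cores differ only by chloro in place of hydrogen on an aromatic carbon. Among the compounds shown, this change has been seen once, with the chloro absent.

Compound 4 is expected to give 1600 nM in this assay. The estimated range for compound 4 runs from 750 nM to 3500 nM. The estimated step is a 3.3-fold lower number from compound 3 to compound 4 (0.52 log units; beyond the scatter), set to match the earlier one because the same change produced a 3.4-fold lower number from compound 1 to compound 2 (0.53 log units; beyond the scatter) and because adding the chloro gave only a 1.1-fold lower number from compound 1 to compound 3 (0.03 log units; within the scatter). Among the compounds with values here, only one prior example carries the expectation, so the range is kept wide.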

Compound 4, half-maximal inhibitory concentration: 1550 nM
Compound 4: middle estimate off by 1.0-fold (0.01 log units), on the high side; the range from low to high includes it.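

In this assay the move from 4-bromophenyl to 4-methoxyphenyl carries over to the chloro-bearing core at full size, a 3.4-fold lower number from compound 3 to compound 4 (0.53 log units; beyond the scatter), and it matches the step on the core of compound 1: the same change on two cores in this assay, a 3.4-fold lower number (0.53 log units; beyond the scatter) from compound 1 to compound 2 and a 3.4-fold lower number (0.53 log units; beyond the scatter) from compound 3 to compound 4, 1.0-fold (0.01 log units) apart, within the scatter of two such steps. Seen from the other side of the same square, adding the chloro leaves the number on the methoxy series within the scatter, a 1.1-fold lower number from compound 2 to compound 4 (0.04 log units; within the scatter), just as it does on the bromo series, so the two changes behave independently across these four compounds: the same change on two cores in this assay, a 1.1-fold lower number (0.03 log units; within the scatter) from compound 1 to compound 3 and a 1.1-fold lower number (0.04 log units; within the scatter) from compound 2 to compound 4, 1.0-fold (0.01 log units) apart, within the scatter of two such steps. Going by these compounds alone, this shows transfer between only two cores that themselves read as alike in this assay, so it does not show that the step would hold on a core where the change on the other aryl ring moves the number, and a whole-cell cytotoxicity read-out does not say how the step arises.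

Still open, going by these compounds, is whether the trend on the anilide ring extends to an amine or a carboxylic acid in the same place, or to a chain longer than methoxy. Also open, on these data alone, is whether a group other than chloro on the other aryl ring, such as a nitrile, would leave the number as unmoved and keep the methoxy step intact.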